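Fluorine at the ester-bearing benzyl arm of compound 2

This account rests on a few compounds, and the source may have more. Where it says the series, first, only, none or still open, it means among the compounds named here.

Compound 1 `O=c1c2cnn(-c3ccc(F)cc3)c2ncn1CC1(O)CCN(Cc2ccc(Cl)cc2)CC1`: 8000 nM
Compound 2 `COC(=O)c1cccc(CN2CCC(O)(Cn3cnc4c(cnn4-c4ccc(F)cc4)c3=O)CC2)c1`: "not determined" (no result reported)

In an assay on Sf21 cells for inhibition of ubiquitin carboxyl-terminal hydrolase 7 (Homo sapiens), read by spectrophotometry, with stated times of 30 min and 2 h (on this read-out lower numbers stand for stronger inhibition and higher numbers for weaker inhibition), compound 1 gives 8000 nM. Within the data shown here, for compound 2 the outcome is "not determined" (no result reported), so it stands nowhere on the numbers; the only anchor is compound 1. Compound 3 `COC(=O)c1ccc(CN2CCC(O)(Cn3cnc4c(cnn4-c4ccc(F)cc4)c3=O)CC2)c(F)c1` differs from compound 2 by 2-fluoro-4-(methoxycarbonyl)phenyl in place of 3-(methoxycarbonyl)phenyl on a saturated chain carbon bound to an amine nitrogen in a ring. Among the measured compounds shown here, with no step between measured compounds to draw on, no shift beyond the scatter is expected in this assay, in either direction. Compound 3 is accordingly estimated at 8000 nM, within a range from 2000 nM to 30000 nM.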

Compound 3, half-maximal inhibitory concentration: 800 nM
Compound 3: middle estimate off by 10-fold (1.00 log units), on the high side; the whole stated range lies above it.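

In this assay the group on a saturated chain carbon bound to an amine nitrogen in a ring proves able to move the read-out: 2-fluoro-4-(methoxycarbonyl)phenyl in place of 4-chlorophenyl gives a 10-fold lower number from compound 1 to compound 3 (1.00 log units; beyond the scatter). As far as these compounds go, the step between compound 2 and compound 3 cannot be read, so the share of the fluorine alone stays unknown. Nothing measured here accounts for the shift. From the compounds shown here alone, whether the methoxycarbonyl group is needed remains open, as does what a carboxylic acid or a primary amide would do in its place.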